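Trading six fluorines for a carbon ring

The source may report more compounds than this note shows. Statements on the series, on what has been measured and on what is new or still open speak of the compounds shown alone.

Values in an in vitro ADME assay on microsomes from Gut (Homo sapiens) for metabolic stability, using NADPH; a higher number here means faster removal of the compound, a lower number slower removal:
- Compound 1 `CC(O)CCNC(=O)c1cc2cc(C#N)ccc2n1Cc1cccc(OC(F)(F)F)c1`: < 6 mL.min-1.g-1 (a limit)
- Compound 2 `N#Cc1ccc2c(c1)cc(C(=O)NCCC(O)C(F)(F)F)n2Cc1cccc(OC(F)(F)F)c1`: 26 mL.min-1.g-1
- Compound 3 `N#Cc1ccc2c(c1)cc(C(=O)NCCC(O)(C(F)(F)F)C(F)(F)F)n2Cc1cccc(OC(F)(F)F)c1`: < 6 mL.min-1.g-1 (a limit)

Compound 3 stands at the limit of < 6 mL.min-1.g-1 in this assay, at which 2 of the 3 values shown sit, and that is a limit, not a number. Compound 4 `CC(O)C1(CNC(=O)c2cc3cc(C#N)ccc3n2Cc2cccc(OC(F)(F)F)c2)CCCC1` changes its side chain: a group of 8 heavy atoms (7 carbon, 1 oxygen; one five-membered non-aromatic ring of carbon only) in place of a group of 11 heavy atoms (4 carbon, 1 oxygen, 6 fluorine; no ring), on a saturated chain carbon bound to an amide-type nitrogen.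

Going by the values given here, three measured steps bear on this change, all within the same side chain. Putting in one trifluoromethyl gave an at least 4.3-fold higher number from compound 1 to compound 2 (0.63 log units; beyond the scatter), and a second one gave an at least 4.3-fold lower number from compound 2 to compound 3 (0.63 log units; beyond the scatter). The direct comparison gives a step that the two limits leave unreadable from compound 1 to compound 3, as both ends are limits. Fluorine therefore moved the number up once and down once, so these steps set no single direction.

The entering group has no fluorine, and compound 1, whose side chain also has none, gives < 6 mL.min-1.g-1, again a limit. Among the compounds with values here, no measured compound carries the new ring. Compound 2 at 26 mL.min-1.g-1 shows that a measurable number is possible with this core, so a modest rise in this assay is expected.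

The expected change is an at least 2.0-fold higher number from compound 3 to compound 4 (0.30 log units; that floor lies within the scatter), though it would be unreadable if another limit came back. For compound 4 the estimated value is 12 mL.min-1.g-1, with an expected range from 6 mL.min-1.g-1 to 40 mL.min-1.g-1.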

Compound 4, intrinsic clearance in microsomes: 99 mL.min-1.g-1
The estimate for compound 4 lay 8.3-fold (0.92 log units) below the measured number, outside the stated range (above it).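

In this assay, replacing the fluorinated side chain with the one carrying the five-membered carbon ring gives an at least 16-fold higher number from compound 3 to compound 4 (1.21 log units; beyond the scatter), and the fluorine-free side chain with no ring gives way to the same ring side chain with an at least 16-fold higher number from compound 1 to compound 4 (1.21 log units; beyond the scatter), so a side chain without fluorine does not by itself keep the number low at this position. Going by these compounds alone, the only comparison with two real numbers gives a 3.8-fold higher number from compound 2 to compound 4 (0.58 log units; beyond the scatter), which makes compound 4 the fastest-removed compound of the four, ahead of the single trifluoromethyl side chain that had marked the top of the series. Compound 3 is a limit and so is compound 1, so the two larger steps give only a floor for the rise: the limit of < 6 mL.min-1.g-1 in this assay, at which 2 of the 4 values shown sit.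

The compounds shown leave open whether the rise belongs to the five-membered ring itself or simply to the extra carbons, which an open chain of the same carbons in the ring's place could separate. They also leave open whether a fluorine, an amine or a carboxylic acid placed on the ring would bring the number back down.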